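The source may hold more compounds than are shown below. What is called first, only, known or untested is meant among the compounds shown, and "the series" means these compounds.

Values measured so far in a functional assay on MDA-MB-231 cells (Homo sapiens) for cytotoxicity, read by sulforhodamine B assay (on this read-out higher numbers stand for lower toxicity in this test and lower numbers for higher toxicity in this test), are these:
- compound 1 `COC1=C(Br)[C@H](O)[C@@]2(C=C1Br)CC(C(=O)NCCCCCNC(=O)C1=NO[C@]3(C=C(Br)C(=O)[C@@H](Br)[C@@H]3O)C1)=NO2` at 8200 nM
- compound 2 `COC1=C(Br)[C@H](O)[C@@]2(C=C1Br)CC(C(=O)NCCCCNC(=O)C1=NO[C@]3(C=C(Br)C(=O)[C@@H](Br)[C@@H]3O)C1)=NO2` at 7600 nM
- compound 3 `COC1=C(Br)[C@H](O)[C@@]2(C=C1Br)CC(C(=O)NCCCCCNC(=O)C1=NO[C@]3(C=C(Br)C(OC)(OC)[C@@H](Br)[C@@H]3O)C1)=NO2` at 9600 nM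

Compound 1 at 8200 nM lies within the usual scatter of both other compounds, so the three numbers form one cluster with no order among them.

The next compound to consider is compound 4 `COC1=C(Br)[C@H](O)[C@@]2(C=C1Br)CC(C(=O)NCCCCCNC(=O)C1=NO[C@]3(C=C(Br)C(=O)[C@H](Br)[C@@H]3O)C1)=NO2` and its relation to compound 1 is the two compounds have the same atoms and bonds and differ only in configuration as drawn: 1 of 5 stereo elements differ; a stereocentre at a saturated ring carbon is drawn S in compound 1 and R in compound 4 in the drawn structures. The two compounds have the same atoms and bonds, and a stereocentre at a saturated ring carbon is drawn S in compound 1 and R in compound 4.

Among the compounds with values here, no measured pair isolates a change of configuration, so the step in this assay has no direct precedent. Within the data shown here, the only guide is the cluster itself, with compound 2 at 7600 nM and compound 3 at 9600 nM both within the scatter of compound 1. The expectation is therefore no step beyond the scatter and no firm direction, though the data cannot show whether this centre matters, so the range is kept wide.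

The expected change is a 1.0-fold higher number from compound 1 to compound 4 (0.02 log units; within the scatter) and it is estimated to stay within the scatter. For compound 4 the estimated value is 8500 nM with an expected range of 4500 nM to 16000 nM on this read-out.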

Compound 4, concentration lethal to 50% of the cells: 6700 nM
For compound 4 the middle estimate is 1.3-fold (0.10 log units) above the measured one; measured number inside the range.
By their numbers in this assay, from the lowest: compounds 4, 2, 1 and 3 (each within the scatter of the next).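

In this assay the series now holds its first pair that isolates configuration, at a stereocentre at a saturated ring carbon, and this pair gives a 1.2-fold lower number from compound 1 to compound 4 (0.09 log units; within the scatter). Drawing this stereocentre R in place of S therefore produces no readable change in this assay, and compound 4 joins the one cluster already formed by the other three compounds. The step can be read as belonging to this centre alone, since nothing else separates the pair: the fact that compounds 1 and 4 differ only in the configuration as drawn.

Still open, from the compounds shown here alone, is whether the other stereo elements of the 5 can be changed with as little effect in this assay, and whether the same change at this centre would read the same way on the shorter chain of compound 2 or with the two methoxy groups of compound 3. Also open, going by these compounds, is how the cluster would respond to a larger change in the structure, such as a longer chain between the two amides or an amine in that chain.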